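Benzylselanyl for methylsulfanyl: the second pair in the series

The source may report more compounds than this note shows. Statements on the series, on what has been measured and on what is new or still open speak of the compounds shown alone.

Compound 3 `CS/C(=N\C(=O)c1cccs1)NC(=O)c1cccs1` was tested in a functional assay on MCF7 cells (Homo sapiens) for cytotoxicity, read by MTT assay, with a stated time of 72 h; on this read-out higher numbers stand for lower toxicity in this test and lower numbers for higher toxicity in this test. In this assay compound 3 reaches only the limit, giving > 100000 nM. Compound 2 `O=C(/N=C(/NC(=O)c1cccs1)[Se]Cc1ccccc1)c1cccs1` carries a group of 8 heavy atoms (7 carbon, 1 selenium; one six-membered aromatic ring of carbon only) in place of a group of 2 heavy atoms (1 carbon, 1 sulfur; no ring), on a carbon with a double bond to nitrogen. In this assay compound 2 also stops at the limit, giving > 100000 nM. The step that the two limits leave unreadable from compound 3 to compound 2 is therefore not readable in size. Compound 1 `CS/C(=N\C(=O)c1ccco1)NC(=O)c1ccco1` has a different core from compound 3; the difference between the two cores is not broken down here. In this assay compound 1 likewise sits at the limit, giving > 100000 nM. Compound 4 `O=C(/N=C(/NC(=O)c1ccco1)[Se]Cc1ccccc1)c1ccco1` carries the same change on the core of compound 1, namely (a group of 8 heavy atoms (7 carbon, 1 selenium; one six-membered aromatic ring of carbon only) in place of a group of 2 heavy atoms (1 carbon, 1 sulfur; no ring), on a carbon with a double bond to nitrogen). The step from compound 1 to compound 4 is expected to be about a step that the limit leaves unreadable from compound 1 to compound 4 because the limit of > 100000 nM in this assay, at which 3 of the 3 values shown sit, leaves no measured value to move from. Compound 4 is expected to give around 150000 nM, most likely between 60000 nM and 500000 nM, and most probably again only as a limit.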

Compound 4, concentration lethal to 50% of the cells: > 100000 nM
Compound 4: no number, only a limit; the forecaster's own chance of this, stated with the estimate: 80%; the middle value lies beyond the limit too.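

Compound 1 and compound 4 both stop at a limit in this assay, so no step between them can be read: the limit of > 100000 nM in this assay, at which 4 of the 4 values shown sit.

The compounds shown leave open whether replacing methylsulfanyl shifts the toxicity on either core, and by how much.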